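The source may report more compounds than this note shows. Statements on the series, on what has been measured and on what is new or still open speak of the compounds shown alone.

Measured so far in a functional assay on HepG2 cells (Homo sapiens) for antiproliferative activity, read by MTT assay; a higher number here means a weaker inhibitor, a lower number a stronger inhibitor:

- compound 1, `Nc1c(C(=O)N/N=C/c2ccc(Cl)cc2)oc2nc(-c3cccs3)cc(C(F)(F)F)c12`: 8100 nM
- compound 2, `CNC(=O)c1oc2nc(-c3cccs3)cc(C(F)(F)F)c2c1N`: 12300 nM
- compound 3, `Nc1c(C(=O)NC2CCCC2)oc2nc(-c3cccs3)cc(C(F)(F)F)c12`: 20800 nM

Compound 3 carries the highest number of the three. Its gap to compound 2 is small, a 1.7-fold higher number from compound 2 to compound 3 (0.23 log units; within the scatter), and falls within the scatter, so no order between compound 2 and compound 3 can be claimed. Its gap to compound 1 is larger, a 2.6-fold higher number from compound 1 to compound 3 (0.41 log units; beyond the scatter), and lies beyond the scatter.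

Compound 4, `Cc1ccc(/C=N/NC(=O)c2oc3nc(-c4cccs4)cc(C(F)(F)F)c3c2N)cc1`, is the next member. Relative to compound 3 the change is a group of 9 heavy atoms (8 carbon, 1 nitrogen; one six-membered aromatic ring of carbon only) in place of a group of 5 heavy atoms (5 carbon; one five-membered non-aromatic ring of carbon only), on an amide-type nitrogen.

Among the measured compounds shown here, two measured steps bear on this. From compound 1 to compound 3 a group with one six-membered aromatic ring on the amide-type nitrogen gave way to cyclopentyl and the number rose, a 2.6-fold higher number from compound 1 to compound 3 (0.41 log units; beyond the scatter). From compound 1 to compound 2 the same aromatic-bearing group gave way to methyl with only a 1.5-fold higher number from compound 1 to compound 2 (0.18 log units; within the scatter). Compound 4 reverses the first of these: cyclopentyl leaves and a group with one six-membered aromatic ring enters in its place, roughly the reverse of the step seen from compound 1 to compound 3. For compound 4 the expected step is therefore a modest fall in the number: a 2.4-fold lower number from compound 3 to compound 4 (0.39 log units; beyond the scatter).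

For compound 4 the estimate in this assay is 8500 nM, with a range from 4000 nM to 18000 nM.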

Compound 4, half-maximal inhibitory concentration: 19800 nM
Beside the measured number, compound 4's estimate is 2.3-fold (0.37 log units) below it; measured number above the stated range.
By their numbers in this assay, from the lowest: compounds 1, 2, 4 and 3 (each within the scatter of the next, the first and the last beyond it).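

In this assay, the larger group with its six-membered aromatic ring on the amide-type nitrogen does not by itself set this member apart from the smaller groups: a 1.1-fold lower number from compound 3 to compound 4 (0.02 log units; within the scatter), and a 1.6-fold higher number from compound 2 to compound 4 (0.21 log units; within the scatter), so no order can be claimed against cyclopentyl or methyl at this position. Among the compounds shown here, the one step here beyond the scatter comes from a single change on the aromatic ring, methyl in place of chloro on an aromatic carbon: a 2.4-fold higher number from compound 1 to compound 4 (0.39 log units; beyond the scatter). For the compounds shown here, the earlier gap between compound 1 and compound 3 therefore cannot be credited to the aromatic ring alone, since the methyl-bearing analogue, compound 4, does not share it, and the chloro group is the only structural difference between compound 1 and compound 4.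

Nothing available explains why the chloro and methyl analogues differ.

On these data alone, whether a fluoro or methoxy group, or a bare aromatic ring, in place of the chloro would fall with compound 1 or with compound 4 stays open. So does whether an amine or a longer chain on the amide-type nitrogen would move the number beyond the scatter of the methyl and cyclopentyl amides.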